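The source may hold more compounds than are shown below. What is called first, only, known or untested is meant among the compounds shown, and "the series" means these compounds.

The study concerns antiproliferative activity in a functional assay on SW-620 cells (Homo sapiens) for antiproliferative activity, read by MTT assay, with a stated time of 72 h; a higher number here means a weaker inhibitor, a lower number a stronger inhibitor. Going by the values given here, compound 1, `Cc1c(CC(O)CO)n(COCC[Si](C)(C)C)c(=O)[nH]c1=O`, is the first of the two measured compounds. In this assay compound 1 gives only a limit of the assay, > 100000 nM. Compound 2, `COCn1c(CC(O)COCc2ccccc2)c(C)c(=O)[nH]c1=O`, is the second. In this assay compound 2 also returns only a limit of the assay, > 100000 nM. Compound 2 therefore stands at the edge of what the assay can report rather than at a number, and the same is true of everything measured here, as the limit of > 100000 nM in this assay, at which 2 of the 2 values shown sit, shows. Compound 3, `COCn1c(CC(O)CO)c(C)c(=O)[nH]c1=O`, differs from compound 2 by hydrogen in place of benzyl on an oxygen on a saturated carbon, the same difference read one bond further out being benzyloxy to hydroxy. Among the compounds with values here, no step between two measured compounds has been recorded, so no size of change has been observed. Compound 3 is expected to show no shift beyond the scatter, an expected step that the limit leaves unreadable from compound 2 to compound 3. Compound 3 is accordingly estimated at 150000 nM, expected within 40000 nM and 500000 nM, and most probably reported once more only as a limit.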

Compound 3, half-maximal inhibitory concentration: > 100000 nM
Compound 3 was reported as a limit; the forecaster's own chance of this, stated with the estimate: 85%; the middle value lies beyond the limit too.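

Compound 1, compound 2 and compound 3 all return only a limit in this assay, so no step among them can be read: the limit of > 100000 nM in this assay, at which 3 of the 3 values shown sit.

The compounds shown leave open what actual value any of the three would give in this assay, and whether hydrogen in place of benzyl changes that value at all.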